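Trifluoromethoxy in Place of Bromo on the Aryl Ether

This account rests on a few compounds, and the source may have more. Where it says the series, first, only, none or still open, it means among the compounds named here.

Compound 1 `Cc1nnsc1CO/N=C/c1c(C)nn(C)c1Oc1cccc(F)c1` and compound 2 `Cc1nnsc1CO/N=C/c1c(C)nn(C)c1Oc1ccc(Br)cc1` share one core and differ only in the aromatic ring on the ether oxygen. In a functional assay on HCT-116 cells (Homo sapiens) for inhibition, read by MTT assay, with a stated time of 48 h (on this read-out lower numbers stand for stronger inhibition and higher numbers for weaker inhibition), compound 1 reaches only the limit of the assay, > 50000 nM. In this assay, among the measured compounds shown here, compound 2 gives 7190 nM, which is the only number recorded in this set. The step of an at least 6.9-fold lower number from compound 1 to compound 2 (0.84 log units; beyond the scatter) is known only as a bound because the limit of > 50000 nM in this assay, at which 1 of the 2 values shown sits, sits at the limit.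

Compound 3 `Cc1nnsc1CO/N=C/c1c(C)nn(C)c1Oc1ccc(OC(F)(F)F)cc1` is the next step from compound 2: trifluoromethoxy in place of bromo on an aromatic carbon. For the measured compounds named here, the single measured step concerned a change from 3-fluorophenyl to 4-bromophenyl, not an exchange of one group on the same aromatic carbon for another, so it bears only loosely on this change. Going by the values given here, with no closer precedent, the step of a 1.1-fold higher number from compound 2 to compound 3 (0.05 log units; within the scatter) is expected to stay within the usual scatter, in no clear direction. Compound 3 is therefore estimated to give 8000 nM in this assay, with a range from 3000 nM to 25000 nM.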

Compound 3, half-maximal inhibitory concentration: 12800 nM
Compound 3: middle estimate off by 1.6-fold (0.20 log units), on the low side; low and high end bracket the measured number.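

Unlike the earlier step, which is known only as a bound, a 1.8-fold higher number from compound 2 to compound 3 (0.25 log units; within the scatter) in this assay joins two measured numbers, so this is the first reading in the set that has a size and not only a bound. It shows that on this aromatic carbon, para to a large group, trifluoromethoxy and bromo cannot be told apart in this read-out, and neither compound 2 nor compound 3 can be ranked above the other. Compound 1 remains a limit and not a number: the limit of > 50000 nM in this assay, at which 1 of the 3 values shown sits.

The compounds shown leave open whether this aromatic carbon would accept groups of a different kind equally well, such as an amine, a carboxylic acid or a longer alkyl chain, for none of these stands among them. Also open, going by these compounds, is how much of the gap between compound 1 and compound 2 belongs to the halogen and how much to its place on the ring, as the two compounds differ in both at once, and how bromo or trifluoromethoxy would read where compound 1 carries its fluoro.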